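Removing a fluoro from a sulfonyl aryl group

This account rests on a few compounds, and the source may have more. Where it says the series, first, only, none or still open, it means among the compounds named here.

Compound 1 `Cc1cc(F)ccc1S(=O)(=O)N1CCN(c2ccc(C(=O)NCc3ccc(F)cc3)nn2)CC1` is one of two measured compounds. In an ADME assay on microsomes from liver (Mus musculus), read by LC-MS, using NADPH, tested at 10 uM (a higher number here means that the liver removes a larger share of the compound in one pass, a lower number that the liver removes a smaller share), compound 1 gives 0.8. Compound 2 `O=C(NCc1ccccc1)c1ccc(N2CCC(S(=O)(=O)c3cccc(Cl)c3Cl)CC2)nn1` gives 0.75 in this assay, a number within the usual scatter of that of compound 1. Compound 3 `Cc1ccccc1S(=O)(=O)N1CCN(c2ccc(C(=O)NCc3ccc(F)cc3)nn2)CC1` differs from compound 1 by hydrogen in place of fluoro on an aromatic carbon, which turns a (4-fluoro-2-methylphenyl)sulfonyl into a (2-methylphenyl)sulfonyl. Among the measured compounds shown here, no step between measured compounds shows what such a change does here, so the step from compound 1 to compound 3 is expected to stay within the scatter, no change at the digits printed from compound 1 to compound 3 (within the scatter). Compound 3 is therefore estimated at 0.8, with a range from 0.65 to 0.9.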

Compound 3, hepatic extraction ratio: 0.7
Beside the measured number, compound 3's estimate is 0.10 above it, and the stated range covers the measured number.
By their numbers in this assay, from the lowest: compounds 3, 2 and 1 (each within the scatter of the next).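

Swapping the fluoro on the (4-fluoro-2-methylphenyl)sulfonyl group for hydrogen gives a number 0.10 lower from compound 1 to compound 3 (within the scatter) in this assay, so this one change on the shared core does not separate the two compounds in this read-out. Nothing measured here offers an explanation for this result. The compounds shown leave open whether a different group on this aromatic carbon, such as a methoxy group, an amine or a carboxylic acid, would move the number beyond the scatter, and whether replacing the methyl group would do so.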